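Selenium for sulfur in compound 1: outlook for compound 4

This account rests on a few compounds, and the source may have more. Where it says the series, first, only, none or still open, it means among the compounds named here.

Measured so far in a functional assay on HeLa cells (Homo sapiens) for antiproliferative activity, read by MTT assay, with a stated time of 48 h; a lower number here means a stronger inhibitor, a higher number a weaker inhibitor:
compound 1 `COc1ccc2c(/C=C/C(=O)c3cc(OC)c(OC)c(SC)c3)c[nH]c2c1`: 131 nM
compound 2 `COc1cc(C(=O)/C=C/c2c[nH]c3ccccc23)cc(SC)c1OC`: 159 nM
compound 3 `COc1ccc2c(/C=C/C(=O)c3cc(OC)c(OC)c(SC)c3)cn(C)c2c1`: 167 nM

Compound 1 gives the lowest of the three numbers, but neither neighbour is separated from it by more than the scatter: a 1.2-fold higher number from compound 1 to compound 2 (0.08 log units; within the scatter) and a 1.3-fold higher number from compound 1 to compound 3 (0.11 log units; within the scatter). The three measured compounds are therefore indistinguishable on these data.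

Compound 4 `COc1ccc2c(/C=C/C(=O)c3cc(OC)c(OC)c([Se]C)c3)c[nH]c2c1` differs from compound 1 in one place: a group of 2 heavy atoms (1 carbon, 1 selenium; no ring) in place of a group of 2 heavy atoms (1 carbon, 1 sulfur; no ring), on an aromatic carbon. For the measured compounds named here, no measured step touches this group; the two steps known, from compound 1 to compound 2 and from compound 1 to compound 3, alter other parts of the molecule and both stay within the scatter. Going by the values given here, for the swap of selenium for sulfur there is no direct precedent here, so the expectation rests only on the flatness of the series so far. Compound 4 is expected to land close to compound 1, with a step of a 1.2-fold lower number from compound 1 to compound 4 (0.08 log units; within the scatter) that does not exceed the scatter. The estimate for compound 4 is 110 nM, with a range from 50 nM to 250 nM.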

Compound 4, half-maximal inhibitory concentration: 104 nM
Compound 4: middle estimate off by 1.1-fold (0.02 log units), on the high side, and the stated range covers the measured number.
By their numbers in this assay, from the lowest: compounds 4, 1, 2 and 3 (each within the scatter of the next).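

In this assay, the group on this aromatic carbon now has a step of its own, and the swap of selenium for sulfur stays within the scatter: a 1.3-fold lower number from compound 1 to compound 4 (0.10 log units; within the scatter). The earlier steps shown here changed other parts of the molecule, whereas this one shows that the methylsulfanyl group itself can be exchanged for its selenium counterpart without a readable difference in this read-out. The data available give no explanation for this flat result.

The compounds shown leave open whether this position responds to any change at all, as both groups compared here have the same heavy-atom count and neither differs from the other beyond the scatter. From the compounds shown here alone, a longer chain, an amine or a carboxylic acid on this carbon would test that limit, and it also remains open whether the selenium swap would behave alike in compound 2 or compound 3.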